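Swapping the sulfonamide heterocycle in a chromone inhibitor

The compounds below may be only part of what the source reports. "The series", "measured", "known", "first", "only" and "open" are said of these compounds alone.

Two related compounds have been measured in an assay on isolated protein for inhibition of alkaline phosphatase, tissue-nonspecific isozyme (Bos taurus), read by spectrophotometry, with stated times of 10 min and 30 min; on this read-out lower numbers stand for stronger inhibition and higher numbers for weaker inhibition. Compound 1 `CCOC1Oc2ccc(F)cc2C(=O)/C1=C/Nc1ccc(S(=O)(=O)Nc2nnc(C)s2)cc1` gives 21000 nM in this assay. Compound 2 `CCOC1Oc2ccccc2C(=O)/C1=C/Nc1ccc(S(=O)(=O)Nc2nnc(C)s2)cc1` gives 250 nM in this assay. Among the compounds with values here, the only change between them is an 84-fold lower number from compound 1 to compound 2 (1.92 log units; beyond the scatter). Within the data shown here, on the two numbers at hand, compound 2 therefore stands as the lower of the two, with compound 1 the only comparison.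

Compound 3 `CCOC1Oc2ccccc2C(=O)/C1=C/Nc1ccc(S(=O)(=O)Nc2cc(OC)nc(OC)n2)cc1` is not yet measured. It keeps everything in compound 2 except the group on the sulfonamide nitrogen, where the change is 2,6-dimethoxypyrimidin-4-yl in place of 5-methyl-1,3,4-thiadiazol-2-yl on a sulfonamide nitrogen. Among the measured compounds shown here, no measured step touches this part of the molecule: the single step known concerns a fluoro substituent on a different ring, so it says nothing about how the sulfonamide heterocycle affects this assay. The expected size of the step from compound 2 to compound 3 is thus genuinely uncertain, and the estimate of a 1.6-fold higher number from compound 2 to compound 3 (0.20 log units; within the scatter) is set near no change with a wide band. Compound 3 is estimated at 400 nM in this assay, within a range from 60 nM to 3000 nM.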

Compound 3, inhibition constant: 23000 nM
For compound 3 the middle estimate is 58-fold (1.76 log units) below the measured one; the whole stated range lies below it.
By their numbers in this assay, from the lowest: compound 2; then compounds 1 and 3 (each within the scatter of the next).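

In this assay, the group on the sulfonamide nitrogen proves to be a sensitive position: 2,6-dimethoxypyrimidin-4-yl in place of 5-methyl-1,3,4-thiadiazol-2-yl gives a 92-fold higher number from compound 2 to compound 3 (1.96 log units; beyond the scatter). This shows that the shared core has a second place where a single change has a large effect on the number, alongside the hydrogen in place of fluoro on an aromatic carbon, which gave an 84-fold lower number from compound 1 to compound 2 (1.92 log units; beyond the scatter). The swap alters the ring size, the hetero atoms and the number of heavy atoms all at once, and nothing available explains why the step from the thiadiazole to the pyrimidine group is so large.

The compounds shown leave open whether the higher number goes with the six-membered ring itself or with its two methoxy groups, a question that a plain pyrimidin-4-yl group on the same nitrogen would help to settle. They also leave open whether a smaller change to the thiadiazole, such as an ethyl or an amino group in place of its methyl, would keep the number of compound 2 or lower it further.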